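The source may hold more compounds than are shown below. What is called first, only, known or untested is meant among the compounds shown, and "the series" means these compounds.

Measured in a physicochemical assay for solubility, measured as kinetic solubility, with a stated time of 1 h, at pH 7.4; on this read-out lower numbers stand for lower solubility and higher numbers for higher solubility:
- compound 1 `O=C(Nc1nc(-c2ccc(Cl)c(Cl)c2)cs1)c1cccnc1`: 20000 nM
- compound 2 `O=C(NC1=NN(c2ccc(Cl)c(Cl)c2)CC1)c1ccncc1`: 9000 nM
- compound 3 `O=C(NC1=NN(c2ccc(Cl)c(Cl)c2)CC1)c1ccccn1`: 11000 nM

Compound 3 lies within the scatter of both compound 2 and compound 1. Next is compound 4 `O=C(NC1=NN(c2ccc(Cl)c(Cl)c2)CC1)c1ccncc1F`, with this change: 3-fluoropyridin-4-yl in place of pyridin-2-yl on a carbonyl carbon. Among the measured compounds shown here, one measured step bears on it: a 1.2-fold higher number from compound 2 to compound 3 (0.09 log units; within the scatter), which exchanges pyridin-4-yl and pyridin-2-yl on the same carbonyl carbon and stays within the scatter. For the measured compounds named here, no measured step covers the 3-fluoropyridin-4-yl group itself, so the basis is thin. No step beyond the scatter is therefore expected in this assay. The estimated step is a 1.2-fold lower number from compound 3 to compound 4 (0.09 log units; within the scatter). Compound 4 is estimated at 9000 nM, with an expected range from 4500 nM to 18000 nM.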

Compound 4, solubility: 36000 nM
Compound 4: the middle estimate sits 4.0-fold (0.60 log units) below what was measured; measured number above the stated range.
By their numbers in this assay, from the lowest: compounds 2, 3, 1 and 4 (each within the scatter of the next, the first and the last beyond it).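

In this assay, fluoro in place of hydrogen on an aromatic carbon gives a 4.0-fold higher number from compound 2 to compound 4 (0.60 log units; beyond the scatter) and so moves the number beyond the scatter, whereas exchanging pyridin-4-yl for pyridin-2-yl gave only a 1.2-fold higher number from compound 2 to compound 3 (0.09 log units; within the scatter) within it. 3-Fluoropyridin-4-yl in place of pyridin-2-yl on the carbonyl carbon likewise gives a 3.3-fold higher number from compound 3 to compound 4 (0.51 log units; beyond the scatter) beyond the scatter. Nothing measured here accounts for these steps.

Open, as far as these compounds go, is whether fluoro in place of hydrogen on the pyridin-2-yl of compound 3 gives a comparable step. Also open, from the compounds shown here alone, is whether chloro, methoxy or an amine on the same ring would match fluoro.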